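Changing the Chain on the Aromatic Nitrogen

The source may hold more compounds than are shown below. What is called first, only, known or untested is meant among the compounds shown, and "the series" means these compounds.

Compound 2 `COc1ccc(F)cc1-c1cccc(-c2nn(CCCCF)c(=O)o2)c1` stands highest of the two compounds measured in a functional assay on the whole organism (strain Wistar albino) for inhibition, with Rattus norvegicus as the target, read by paw edema, with stated times of 30 min and 0.5 h, at a dose of 10 mg/kg by the oral route (a higher number here means more inhibition at the dose given (going by the name of the read-out), a lower number less inhibition), with compound 2 giving 36%. Compound 1 `COc1ccc(F)cc1-c1cccc(-c2n[nH]c(=O)o2)c1` gives 25% in this assay, and the step of a number 11 percentage points higher from compound 1 to compound 2 (beyond the scatter) is the only one measured. Compound 3 `COc1ccc(F)cc1-c1cccc(-c2nn(CCOC3CCCCO3)c(=O)o2)c1` differs from compound 2 by (oxan-2-yl)oxy in place of 2-fluoroethyl on a saturated chain carbon, two bonds along the chain from an aromatic nitrogen. Among the compounds with values here, no measured step exchanges one chain end for another; the single step only adds a chain where hydrogen stood, so it offers little guidance, and no step beyond the scatter is expected in this assay for a number 3 percentage points lower from compound 2 to compound 3 (within the scatter). Compound 3 is estimated at 33%, within the range 18% to 48%.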

Compound 3, a percentage reported as inhibition, in the whole organism at one dose (the size of the read-out at that dose, not a potency): 16%
The estimate for compound 3 lay 17 percentage points above the measured number; the whole stated range lies above it.
By their numbers in this assay, from the lowest: compounds 3 and 1 (each within the scatter of the next); then compound 2.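

In this assay, the end of the chain on the aromatic nitrogen proves to matter: (oxan-2-yl)oxy in place of 2-fluoroethyl gives a number 20 percentage points lower from compound 2 to compound 3 (beyond the scatter). A chain on that nitrogen does not by itself carry the gain seen with 4-fluorobutyl, since 2-((oxan-2-yl)oxy)ethyl in place of hydrogen gives a number 9 percentage points lower from compound 1 to compound 3 (within the scatter). Nothing available accounts for this difference between the two chains.

On these data alone, whether the fluorine itself counts remains open, as a plain butyl chain would show. So does how a chain ending in an amine or a carboxylic acid would read out.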